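A few compounds are considered here, and "the series" means these few. Any claim that something is new, unique, unknown or untested is made for them only; others in the source may bear on it.

Compound 2 `CC1(C)CNC(=O)c2sc(Nc3ccc(I)cc3F)c(C(=O)N[C@@H]3CCCNC3)c2C1` is the lower of the two numbers recorded in a functional assay on HT-29 cells (Homo sapiens) for antiproliferative activity (on this read-out higher numbers stand for weaker inhibition and lower numbers for stronger inhibition), giving 91 nM. Compound 1 `CC1(C)CNC(=O)c2sc(Nc3ccc(I)cc3F)c(C(=O)NCCCO)c2C1` differs from compound 2 only on the amide-type nitrogen, and in this assay compound 1 gives 6210 nM; the step of a 68-fold lower number from compound 1 to compound 2 (1.83 log units; beyond the scatter) shows how much that one position matters. Compound 3 `CC1(C)CNC(=O)c2sc(Nc3ccc(I)cc3F)c(C(=O)NOC[C@H](O)CO)c2C1` is the next compound, and the change from compound 2 to compound 3 is 2,3-dihydroxypropoxy in place of piperidin-3-yl on an amide-type nitrogen. The group that enters carries hydroxyl groups on a short chain, which resembles the 3-hydroxypropyl of compound 1 more than the ring of compound 2, although it is joined through an oxygen rather than a carbon. Among the compounds with values here, the one measured step that bears on this position was large, and it favoured the ring. A step in the opposite direction is therefore expected here: compound 3 is estimated at 2000 nM, with a range from 400 nM to 10000 nM, meaning an expected step of a 22-fold higher number from compound 2 to compound 3 (1.34 log units; beyond the scatter) in this assay, a weaker number than compound 2 but not necessarily as weak as compound 1.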

Compound 3, half-maximal inhibitory concentration: 1580 nM
Estimate against measurement, compound 3: 1.3-fold (0.10 log units) above, within the range that was stated.
By their numbers in this assay, from the lowest: compound 2; then compound 3; then compound 1.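

In this assay, the piperidin-3-yl of compound 2 now stands apart from two different open chains on the amide-type nitrogen, for 2,3-dihydroxypropoxy in its place gives a 17-fold higher number from compound 2 to compound 3 (1.24 log units; beyond the scatter). The two chains do not read alike either, as a 3.9-fold lower number from compound 1 to compound 3 (0.59 log units; beyond the scatter) shows, although this gap is smaller than the gap from either chain to the ring; this step changes the linking atom and the hydroxyl groups together, so it cannot be assigned to either change alone. Nothing available here explains why the three groups fall in this order.

The compounds shown leave open whether the low number of compound 2 depends on the ring, on its nitrogen or on both: a cyclohexyl group would keep the ring without the nitrogen, and a 3-aminopropyl chain would keep an amine without the ring. A 2,3-dihydroxypropyl group, joined through carbon rather than oxygen, would likewise separate the linking oxygen from the hydroxyl groups.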